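The source may report more compounds than this note shows. Statements on the series, on what has been measured and on what is new or still open speak of the compounds shown alone.

Measured compounds: compound 1 `COc1cc2cc(Oc3ccc(NC(=O)Nc4cccc(C(F)(F)F)c4)cc3)c(C)nc2cc1OC` gives 18900 nM in a functional assay on MCF7 cells (Homo sapiens) for inhibition, read by sulforhodamine B assay, with a stated time of 48 h; on this read-out lower numbers stand for higher toxicity in this test and higher numbers for lower toxicity in this test. Compound 2 `COc1cc2cc(Oc3ccc(NC(=O)Nc4ccc(Cl)c(C(F)(F)F)c4)cc3)c(C)nc2cc1OC` gives 15000 nM in this assay.

Among the compounds with values here, compound 2 holds the lower of the two numbers, but its only neighbour, compound 1, lies within the usual scatter: the step of a 1.3-fold lower number from compound 1 to compound 2 (0.10 log units; within the scatter) is too small to separate them. Compound 3 `COc1cc2cc(Oc3ccc(NC(=O)Nc4ccc(Cl)c(Cl)c4)cc3)c(C)nc2cc1OC` is not yet measured. It differs from compound 2 by chloro in place of trifluoromethyl on an aromatic carbon, so the ring now carries two chloro groups, ortho to each other, in place of one chloro and one trifluoromethyl. Within the data shown here, the single measured step, a 1.3-fold lower number from compound 1 to compound 2 (0.10 log units; within the scatter), concerns a chloro entering for hydrogen and was within the scatter; no measured pair exchanges trifluoromethyl for chloro, so there is no direct guide. Compound 3 is therefore expected to show a step about the size of a 1.2-fold higher number from compound 2 to compound 3 (0.08 log units; within the scatter), not clearly beyond the scatter. For compound 3 the estimate is 18000 nM, with a range from 7000 nM to 45000 nM.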

Compound 3, concentration lethal to 50% of the cells: > 100000 nM
Compound 3: no number, only a limit (the forecaster's own chance of this, stated with the estimate: 10%); at least 5.5-fold (0.74 log units) between middle value and limit.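

In this assay compound 3 gives > 100000 nM, which is a limit of the assay and not a number. Within the data shown here, the exchange of trifluoromethyl for chloro, ortho to a chloro group, is the first change to lie beyond the scatter, with an at least 6.6-fold higher number from compound 2 to compound 3 (0.82 log units; beyond the scatter). The replacement of 3-(trifluoromethyl)phenyl by 3,4-dichlorophenyl points the same way, with an at least 5.2-fold higher number from compound 1 to compound 3 (0.72 log units; beyond the scatter), so the two compounds that keep trifluoromethyl stay within the scatter of each other, while compound 3, which lacks it, shows lower toxicity in this test.

As far as these compounds go, the full size of both steps remains open, as compound 3 rests on a limit: the limit of > 100000 nM in this assay, at which 1 of the 3 values shown sits. Whether a nitrile or an amine at this position would behave like trifluoromethyl or like chloro also remains open.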